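One Changed Stereocentre on a Shared Core

A few compounds are considered here, and "the series" means these few. Any claim that something is new, unique, unknown or untested is made for them only; others in the source may bear on it.

Compound 1 `CO[C@@H]1[C@H]2OC(=O)C[C@H]2O[C@@H]1[C@@H](O)c1ccccc1` gives 15500 nM
Compound 2 `CO[C@@H]1[C@H]2OC(=O)C[C@H]2O[C@@H]1C(=O)c1ccccc1` gives 8970 nM
Compound 3 `O=C1C[C@H]2O[C@H](C(O)O)[C@H](O)[C@H]2O1` gives 18600 nM

All three values come from a functional assay on Jurkat cells (Homo sapiens) for inhibition, read by MTT assay, with a stated time of 72 h (on this read-out higher numbers stand for weaker inhibition and lower numbers for stronger inhibition), and form the background for compound 4 `CO[C@@H]1[C@H]2OC(=O)C[C@H]2O[C@@H]1[C@H](O)c1ccccc1`, which has not yet been measured. Compound 1 (15500 nM) lies within the usual scatter of both compound 2 and compound 3, so it is not clearly separated from either.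

Compound 4 differs from compound 1 only in configuration as drawn (the two compounds have the same atoms and bonds and differ only in configuration as drawn: 1 of 5 stereo elements differ; a stereocentre at a saturated chain carbon is drawn S in compound 1 and R in compound 4): a stereocentre at a saturated chain carbon is drawn S in compound 1 and R in compound 4. The two compounds have the same atoms and bonds. Within the data shown here, no measured pair here isolates a change of this kind, so the data give no direct guide to its size or direction in this assay for this series. Starting from compound 1 (15500 nM), the estimated 1.4-fold lower number from compound 1 to compound 4 (0.15 log units; within the scatter) is expected to stay within the scatter, with only a slight lean towards a lower number. Compound 4 is estimated at 11000 nM with an expected range from 3500 nM to 28000 nM on this read-out.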

Compound 4, half-maximal inhibitory concentration: 24900 nM
Compound 4: the middle estimate sits 2.3-fold (0.35 log units) below what was measured; measured number inside the range.
By their numbers in this assay, from the lowest: compounds 2, 1, 3 and 4 (each within the scatter of the next, the first and the last beyond it).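

Among these compounds, compound 1 and compound 4 form the first pair here that isolates a single change, and the comparison is clean because nothing else separates them: the fact that compounds 1 and 4 differ only in the configuration as drawn. In this assay, switching this stereocentre at a saturated chain carbon from S to R as drawn amounts to a 1.6-fold higher number from compound 1 to compound 4 (0.21 log units; within the scatter), so neither configuration is clearly preferred. On this evidence, the drawn configuration at this carbon does not separate the two compounds by more than repeat measurements could, a finding that holds for this one pair only.

As far as these compounds go, how the other stereo elements of the shared core bear on this read-out stays open. So does whether an amine or a carboxylic acid at this carbon would shift the number beyond the scatter.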